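Working notes: aryl change on the amide nitrogen

The compounds below may be only part of what the source reports. "The series", "measured", "known", "first", "only" and "open" are said of these compounds alone.

Measured so far in a functional assay on A549 cells (Homo sapiens) for inhibition, read by CCK-8 assay, with a stated time of 72 h, tested at 1 uM; a lower number here means less inhibition of growth, a higher number more inhibition of growth at the concentration tested (values after each structure):
compound 1 `COC(=O)c1ccc(NC(=O)C2(C(=O)Nc3ccc(Nc4ncc5cc(C(=O)N(C)C)n(C6CCCC6)c5n4)cc3)CC2)cc1` gives 77.1%
compound 2 `CN(C)C(=O)c1cc2cnc(Nc3ccc(NC(=O)C4(C(=O)Nc5cccc(Br)c5)CC4)cc3)nc2n1C1CCCC1` gives 20.2%

Compound 2 stands at 20.2% in this assay as the lower of the two values, well beyond the scatter from compound 1. Compound 3 `CN(C)C(=O)c1cc2cnc(Nc3ccc(NC(=O)C4(C(=O)Nc5ccc(C(F)(F)F)cc5)CC4)cc3)nc2n1C1CCCC1` has 4-(trifluoromethyl)phenyl in place of 3-bromophenyl on an amide-type nitrogen and is otherwise unchanged. Among the compounds with values here, one measured step bears on this place, a number 56.9 percentage points lower from compound 1 to compound 2 (beyond the scatter), which is large and shows that the group on this nitrogen can move the read-out strongly. The entering group, like the 4-(methoxycarbonyl)phenyl of compound 1 (77.1%), is a 4-substituted phenyl, so a rise is expected, though probably not a full return, and a single pair fixes its size only loosely. The expected change is a number 27.8 percentage points higher from compound 2 to compound 3 (beyond the scatter) in size and direction. In this assay the estimated value for compound 3 is 48%, with the expected range (22% to 75%).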

Compound 3, percent growth inhibition at one concentration: -25.3%
For compound 3 the middle estimate is 73.3 percentage points above the measured one; the whole stated range lies above it.
By their numbers in this assay, from the lowest: compound 3; then compound 2; then compound 1.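

In this assay the step of a number 45.5 percentage points lower from compound 2 to compound 3 (beyond the scatter) shows that a 4-substituted phenyl on this amide-type nitrogen does not in itself bring the read-out back towards that of compound 1; the value falls further instead, and compound 3 is the lowest of the three. The step of a number 102.4 percentage points lower from compound 1 to compound 3 (beyond the scatter), with trifluoromethyl in place of methoxycarbonyl on an aromatic carbon, shows that the group carried by the 4-substituted phenyl can alone span a very wide range of this read-out. The data available give no explanation for either step.

The compounds shown leave open whether the change from 3-bromophenyl to 4-(trifluoromethyl)phenyl acts through the place of the substituent or through its identity, which a 4-bromophenyl would separate. Going by these compounds, it also remains open whether the high value of compound 1 needs the methyl ester itself, or would persist with a carboxylic acid or a primary amide in its place.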